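Carbamate to Trifluoroacetamide on the Side Chain

A few compounds are considered here, and "the series" means these few. Any claim that something is new, unique, unknown or untested is made for them only; others in the source may bear on it.

Compound 2 `COc1cc2ncnc(-n3nc(-c4ccccn4)nc3N)c2cc1OCCCNC(=O)OCC(F)(F)F` was tested in an assay on MCF7 cells for inhibition of Serine-protein kinase ATM (Homo sapiens), read by immunofluorescence, with a stated time of 1 h (a lower number here means a stronger inhibitor, a higher number a weaker inhibitor), where compound 2 gives 1200 nM. Among the two compounds measured so far, compound 2 has the highest number; its nearest neighbour is compound 1 `COc1cc2ncnc(-n3nc(-c4ccccn4)nc3N)c2cc1OCCNC(=O)OC(C)(C)C`, which in this assay gives 800 nM. Within the data shown here, the only step between two measured compounds, a 1.5-fold higher number from compound 1 to compound 2 (0.18 log units; within the scatter), alters the side-chain carbamate and stays within the scatter.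

Compound 3 `COc1cc2ncnc(-n3nc(-c4ccccn4)nc3N)c2cc1OCCCNC(=O)C(F)(F)F` differs from compound 2 in one place: trifluoromethyl in place of 2,2,2-trifluoroethoxy on a carbonyl carbon. Among the measured compounds shown here, no measured pair alters the group on this carbonyl carbon, so the only guidance is that the single recorded side-chain change, a 1.5-fold higher number from compound 1 to compound 2 (0.18 log units; within the scatter), produced nothing beyond the scatter. Compound 3 is therefore expected to show no shift beyond the scatter in this assay, the expected change being no change at the digits printed from compound 2 to compound 3 (within the scatter). For the measured compounds named here, the estimate for compound 3 in this assay is 1200 nM, with a range from 400 nM to 3600 nM, the width reflecting that this carbonyl substitution has no direct precedent among the measured compounds.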

Compound 3, half-maximal inhibitory concentration: 2900 nM
Compound 3: the middle estimate sits 2.4-fold (0.38 log units) below what was measured, and the stated range covers the measured number.
By their numbers in this assay, from the lowest: compounds 1 and 2 (each within the scatter of the next); then compound 3.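

In this assay, trifluoromethyl in place of 2,2,2-trifluoroethoxy on a carbonyl carbon comes with a 2.4-fold higher number from compound 2 to compound 3 (0.38 log units; beyond the scatter), so at this end of the side chain the group on the carbonyl carbon can move the number beyond the scatter, which the earlier step, a 1.5-fold higher number from compound 1 to compound 2 (0.18 log units; within the scatter), did not show. The larger replacement, (((trifluoromethyl)carbonyl)amino)methyl in place of (tert-butoxycarbonyl)amino, comes with a 3.6-fold higher number from compound 1 to compound 3 (0.56 log units; beyond the scatter), which places compound 3 clearly apart from both carbamates, while those two remain within the scatter of each other. Nothing available explains why the number rises with this change.

The compounds shown leave open whether the rise follows from the trifluoromethyl group itself or from the absence of an oxygen attached to the carbonyl carbon, a question that a plain methyl group, or an amine forming a urea, on that carbon could address. They also leave open how a free primary amine, a carboxylic acid or a longer chain at the end of the side chain would compare with the carbamates of compound 1 and compound 2.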